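Working notes on solubility: three measured compounds, one pending

A few compounds are considered here, and "the series" means these few. Any claim that something is new, unique, unknown or untested is made for them only; others in the source may bear on it.

Measured in a physicochemical assay for solubility, in phosphate buffer, with a stated time of 18 h; a lower number here means a less soluble compound, a higher number a more soluble compound:
compound 1 `N#Cc1c(N)nc2nc(C3CC3)ncc2c1N` gives 23000 nM
compound 2 `N#Cc1c(N)nc2nc(C3CCCCC3)ncc2c1N` gives 81000 nM
compound 3 `CC(C)(C)c1ncc2c(N)c(C#N)c(N)nc2n1` gives 37200 nM

Compound 3 stands second highest of the three numbers. Its nearest neighbour is compound 1: the step of a 1.6-fold higher number from compound 1 to compound 3 (0.21 log units; within the scatter) is within the scatter, so no order between these two is claimed. Its furthest neighbour is compound 2: the step of a 2.2-fold lower number from compound 2 to compound 3 (0.34 log units; beyond the scatter) is modest but beyond the scatter. The widest step in the set, a 3.5-fold higher number from compound 1 to compound 2 (0.55 log units; beyond the scatter), is likewise modest.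

Compound 4 `CC(C)(C)c1nc(CCCCC#N)c2c(N)c(C#N)c(N)nc2n1` differs from compound 3 in one place: 4-cyanobutyl in place of hydrogen on an aromatic carbon. For the measured compounds named here, none of the measured steps bears directly on this change. Going by the values given here, all three exchange one group for another on the same aromatic carbon of the shared core; none adds a chain carrying a nitrile at a second position, so there is no precedent here for the new group. With the largest measured step only modest, no step beyond the scatter is expected in this assay in either direction, though the uncertainty is wider than for a swap among the measured groups. Compound 4 is expected to give 30000 nM, within a range of 8000 nM to 110000 nM. This estimate implies a 1.2-fold lower number from compound 3 to compound 4 (0.09 log units; within the scatter), a step expected to stay within the scatter.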

Compound 4, solubility: 16000 nM
For compound 4 the middle estimate is 1.9-fold (0.27 log units) above the measured one, within the range that was stated.
By their numbers in this assay, from the lowest: compounds 4, 1 and 3 (each within the scatter of the next, the first and the last beyond it); then compound 2.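

Working notes on the new position: in this assay, 4-cyanobutyl in place of hydrogen on the aromatic carbon next to the ring nitrogen gives a modest step beyond the scatter (a 2.3-fold lower number from compound 3 to compound 4 (0.37 log units; beyond the scatter)). For the compounds shown here, the earlier steps only exchanged one group for another on a single aromatic carbon of the shared core, so this is the first reading at this second carbon and the first for a chain ending in a nitrile, and it shows that this position can be substituted with a step of no more than modest size in this assay. The compounds shown hold no measurement that accounts for the direction of this step.

Still open, on these data alone, is whether the step follows from filling this position at all, from the length of the chain or from its terminal nitrile; a methyl group, a shorter or longer alkyl chain, or a butyl chain ending in an amine or a carboxylic acid on the same carbon would separate these readings. Also open, as far as these compounds go, is whether 4-cyanobutyl gives a similar step when the tert-butyl group is replaced by cyclopropyl or cyclohexyl.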